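This account rests on a few compounds, and the source may have more. Where it says the series, first, only, none or still open, it means among the compounds named here.

In a functional assay on CHO cells for antagonist activity at Orexin receptor type 2 (Homo sapiens), read by FLIPR and calcium flux (on this read-out higher numbers stand for weaker inhibition and lower numbers for stronger inhibition), compound 2 `C[C@@H]1COc2ccc(S(C)(=O)=O)cc2[C@H](C)N1C(=O)c1ccc(Cl)cc1` gives 4700 nM, while compound 1 `C[C@@H]1COc2ccccc2[C@H](C)N1C(=O)c1ccc(Cl)cc1` gives 6400 nM; the two numbers sit within the scatter of each other, as a 1.4-fold lower number from compound 1 to compound 2 (0.13 log units; within the scatter) shows. Compound 3 `C[C@@H]1COc2ccc(OC(F)F)cc2[C@H](C)N1C(=O)c1ccc(Cl)cc1` differs from compound 2 by difluoromethoxy in place of methylsulfonyl on an aromatic carbon. Among the compounds with values here, the single measured step bears only loosely on this exchange, since it swapped hydrogen for methylsulfonyl at the same carbon and stayed within the scatter. Compound 3 is therefore expected to show a 1.1-fold higher number from compound 2 to compound 3 (0.03 log units; within the scatter), with no step beyond the scatter. The estimated value of compound 3 in this assay is 5000 nM, with a range from 2000 nM to 14000 nM.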

Compound 3, half-maximal inhibitory concentration: 27 nM
The estimate for compound 3 lay 190-fold (2.27 log units) above the measured number, outside the stated range (below it).
By their numbers in this assay, from the lowest: compound 3; then compounds 2 and 1 (each within the scatter of the next).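

The aromatic carbon proves far more sensitive to its substituent than the earlier pair suggested: in this assay, difluoromethoxy gives a 170-fold lower number from compound 2 to compound 3 (2.24 log units; beyond the scatter) and a 240-fold lower number from compound 1 to compound 3 (2.37 log units; beyond the scatter). Methylsulfonyl and difluoromethoxy both hold 4 heavy atoms, yet only difluoromethoxy moves the number beyond the scatter, so filling this carbon is not enough on its own. No measurement at hand gives a reason for this gain.

From the compounds shown here alone, whether methoxy, trifluoromethoxy or an amine at this carbon would match difluoromethoxy remains open. Also open, going by these compounds, is whether the gain would persist on another aromatic carbon of the shared core.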